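The source may hold more compounds than are shown below. What is called first, only, known or untested is meant among the compounds shown, and "the series" means these compounds.

Within the data shown here, compound 3 `O=C(NCc1ccc(S(=O)(=O)c2cccc(C(F)(F)F)c2)cc1)c1cc2ccncc2o1` gives 48% in an ADME assay on microsomes from liver (Homo sapiens) for metabolic stability, read by LC-MS, with a stated time of 30 min, tested at 1 uM (on this read-out higher numbers stand for a more stable compound and lower numbers for a less stable compound), the lowest of the three numbers so far. Compound 1 `O=C(NCc1ccc(S(=O)(=O)c2cccc(C(F)(F)F)c2)cc1)c1cc2cnccc2[nH]1` gives 81% and compound 2 `O=C(NCc1ccc(S(=O)(=O)c2cc(F)cc(F)c2)cc1)c1cnc2nccn2c1` gives 78%. Both of these numbers lie beyond the scatter from the number of compound 3. Compound 4 `O=C(NCc1ccc(S(=O)(=O)c2cc(F)cc(F)c2)cc1)c1cc2ccncc2o1` brings 3,5-difluorophenyl in place of 3-(trifluoromethyl)phenyl on a sulfonyl sulfur. Among the measured compounds shown here, no measured step isolates this swap. For the measured compounds named here, the one measured step, a number 33 percentage points lower from compound 1 to compound 3 (beyond the scatter), is large but concerns the group on a carbonyl carbon, which compound 4 shares with compound 3. Compound 2 carries 3,5-difluorophenyl, but with a different group on that carbon. No step beyond the scatter is therefore expected in this assay. The estimated change is a number 4 percentage points higher from compound 3 to compound 4 (within the scatter). Compound 4 is expected at 52%, with an estimated range of 38% to 66%.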

Compound 4, percent of the compound remaining: 77%
Estimate against measurement, compound 4: 25 percentage points below, and the stated range ends below it.
By their numbers in this assay, from the lowest: compound 3; then compounds 4, 2 and 1 (each within the scatter of the next).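

On the sulfonyl sulfur, the swap to 3,5-difluorophenyl now stands isolated, with the group on the carbonyl carbon held constant: a number 29 percentage points higher from compound 3 to compound 4 (beyond the scatter) in this assay, so this position does move the read-out. With 3,5-difluorophenyl in place, a number 1 percentage points lower from compound 2 to compound 4 (within the scatter), so these two groups on the carbonyl carbon are not told apart here. No measured data explain the size of the swap.

From the compounds shown here alone, whether the swap gives a similar step alongside the carbonyl group of compound 1 stays open, as does the outcome for plain phenyl or 3-chlorophenyl on the sulfonyl sulfur.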